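The source may hold more compounds than are shown below. What is called first, only, known or untested is meant among the compounds shown, and "the series" means these compounds.

Compound 1 `COc1ccc(C(=O)/C=C\N(C)O)cc1` is the point of departure. For the measured compounds named here, in an assay on RBL-1 cells for inhibition of Polyunsaturated fatty acid 5-lipoxygenase (Rattus norvegicus) (a higher number here means a weaker inhibitor, a lower number a stronger inhibitor), compound 1 gives 6000 nM, the only number it has there, alongside one further entry that yielded no single figure. Compound 2 `CN(O)/C=C\C(=O)c1ccc(OCc2ccccc2)cc1` in this assay gives 1900 nM; 1100 nM (2 entries). Compound 3 `CN(O)/C=C\C(=O)c1ccc(OCc2ccccn2)cc1` differs from compound 1 by pyridin-2-yl in place of hydrogen on a saturated chain carbon bound to an oxygen on an aromatic ring. Going by the values given here, no measured pair shows this exact change, so the step of a 4.0-fold lower number from compound 1 to compound 3 (0.60 log units; beyond the scatter) is expected as a moderate gain in potency, beyond the usual scatter. Compound 3 is therefore estimated at 1500 nM, within a range from 600 nM to 4000 nM.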

Compound 3, half-maximal inhibitory concentration: 10000 nM
Estimate against measurement, compound 3: 6.7-fold (0.82 log units) below; measured number above the stated range.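

At this position, pyridin-2-yl in place of hydrogen gives a 1.7-fold higher number from compound 1 to compound 3 (0.22 log units; within the scatter), so in this assay this larger group brings no clear gain over the small starting compound. Compound 3 gives 10000 nM, whereas compound 2, with phenyl in the same place, gives 1900 nM; 1100 nM (2 entries). That gap is wider than the spread between repeat readings of one compound: the several entries of compound 2 in this assay, 1900 nM; 1100 nM (2 entries)

Going by these compounds, it remains open whether pyridin-3-yl or pyridin-4-yl would behave like phenyl or like pyridin-2-yl. On these data alone, how an amine or a carboxylic acid in this place would read is also open.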